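Compound 3: second chloro-fluorophenyl arrangement on the carbonyl

The source may report more compounds than this note shows. Statements on the series, on what has been measured and on what is new or still open speak of the compounds shown alone.

Going by the values given here, in a functional assay on cells (Mus musculus) for activation of 5-hydroxytryptamine receptor 1F (Homo sapiens), read by GTPgammaS binding (a higher number here means that more compound is needed for the effect, a lower number that less compound is needed), compound 2 `CN1CCC(c2coc3ccc(NC(=O)c4c(F)cccc4Cl)nc23)CC1` gives 68.7 nM, the highest of the two numbers so far, with compound 1 `CN1CCC(c2coc3ccc(NC(=O)c4ccc(F)cc4)nc23)CC1` nearest at 66 nM; the step of a 1.0-fold higher number from compound 1 to compound 2 (0.02 log units; within the scatter) is within the scatter. Compound 3 `CN1CCC(c2coc3ccc(NC(=O)c4ccc(F)cc4Cl)nc23)CC1` differs from compound 2 by 2-chloro-4-fluorophenyl in place of 2-chloro-6-fluorophenyl on a carbonyl carbon. Among the compounds with values here, the only measured step bearing on this, from compound 1 to compound 2, also exchanged one halogen pattern on this ring for another and gave no change beyond the scatter, so no step beyond the scatter is expected in this assay, a 1.1-fold lower number from compound 2 to compound 3 (0.02 log units; within the scatter). Compound 3 is therefore estimated at 65 nM, range 25 nM to 170 nM.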

Compound 3, half-maximal effective concentration: 277 nM
Compound 3: the middle estimate sits 4.3-fold (0.63 log units) below what was measured; measured number outside the range, above it.
By their numbers in this assay, from the lowest: compounds 1 and 2 (each within the scatter of the next); then compound 3.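

In this assay the arrangement of halogens on the phenyl attached to this carbonyl carbon matters: 2-chloro-4-fluorophenyl in place of 2-chloro-6-fluorophenyl, with the same atoms joined differently, gives a 4.0-fold higher number from compound 2 to compound 3 (0.61 log units; beyond the scatter). Chloro in place of hydrogen on an aromatic carbon gives a 4.2-fold higher number from compound 1 to compound 3 (0.62 log units; beyond the scatter), yet compound 2 also carries chloro and stays within the scatter of compound 1, so the presence of chloro alone does not set the number. Nothing available accounts for this difference. Open, going by these compounds, is whether methyl or methoxy in place of the chloro of compound 3 behaves the same way, and where an unsubstituted phenyl on this carbonyl would fall.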